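Swapping the group on a sulfonamide nitrogen

The compounds below may be only part of what the source reports. "The series", "measured", "known", "first", "only" and "open" are said of these compounds alone.

Compound 1 `N=C(N)NS(=O)(=O)c1ccc(N/C(S)=N\c2ccnc3cc(C(F)(F)F)ccc23)cc1`: "not active" (no number reported)
Compound 2 `O=S(=O)(Nc1ccccn1)c1ccc(N/C(S)=N\c2ccnc3cc(C(F)(F)F)ccc23)cc1`: 49300 nM
Compound 3 `Cc1cc(C)nc(NS(=O)(=O)c2ccc(N/C(S)=N\c3ccnc4cc(C(F)(F)F)ccc34)cc2)n1`: 52900 nM

These values come from a functional assay on MDA-MB-231 cells (Homo sapiens) for antiproliferative activity, read by sulforhodamine B assay, with a stated time of 48 h; on this read-out higher numbers stand for weaker inhibition and lower numbers for stronger inhibition. Compound 1 has no single number in this assay; it was reported as not active, so there is no starting value to build from. Compound 4 `COc1ncnc(NS(=O)(=O)c2ccc(N/C(S)=N\c3ccnc4cc(C(F)(F)F)ccc34)cc2)c1OC` differs from compound 1 at one place: a group of 10 heavy atoms (6 carbon, 2 nitrogen, 2 oxygen; one six-membered aromatic ring with 2 hetero atoms) in place of a group of 3 heavy atoms (1 carbon, 2 nitrogen; no ring), on a sulfonamide nitrogen. For the measured compounds named here, the only measured step in the set, a 1.1-fold higher number from compound 2 to compound 3 (0.03 log units; within the scatter), also swaps one aromatic group for another on that same sulfonamide nitrogen, and it lies within the scatter. Compounds 2 and 3 each carry a ring on that nitrogen, as compound 4 does, and both sit in the same weak region. Compound 4 is therefore expected to land near them, because compound 2 gives 49300 nM and compound 3 gives 52900 nM. Compound 4 is estimated at about 50000 nM, with a range from 20000 nM to 150000 nM.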

Compound 4, half-maximal inhibitory concentration: 83000 nM
Estimate against measurement, compound 4: 1.7-fold (0.22 log units) below; the measured number falls inside the stated range.
By their numbers in this assay, from the lowest: compounds 2, 3 and 4 (each within the scatter of the next).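

Putting 5,6-dimethoxypyrimidin-4-yl on the sulfonamide nitrogen gives a 1.6-fold higher number from compound 3 to compound 4 (0.20 log units; within the scatter) and a 1.7-fold higher number from compound 2 to compound 4 (0.23 log units; within the scatter). So far, pyridin-2-yl, 4,6-dimethylpyrimidin-2-yl and 5,6-dimethoxypyrimidin-4-yl cannot be told apart in this read-out, and the step from compound 1 cannot be read, as compound 1 has no number. Nothing measured here explains why these three rings give such similar numbers.

Still open, on these data alone, is whether a ring carrying a carboxylic acid or an amine on that nitrogen would give a number clearly apart from these. The same question stands for a plain alkyl chain there.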